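Swapping an aryl group on the shared anilino nitrogen

The source may report more compounds than this note shows. Statements on the series, on what has been measured and on what is new or still open speak of the compounds shown alone.

Of the compounds shown here, two have been tested so far. Compound 1 `CCS(=O)(=O)Nc1cc(-c2ccc3ncnc(Nc4ccc(OC(F)(F)F)cc4)c3c2)cnc1OC` and compound 2 `CCCCS(=O)(=O)Nc1cc(-c2ccc3ncnc(Nc4ccc(F)c(Cl)c4)c3c2)cnc1OC` share a core and differ in several places. In a functional assay on HCT-116 cells (Homo sapiens) for cytotoxicity, read by sulforhodamine B assay, with a stated time of 72 h (a lower number here means a stronger inhibitor, a higher number a weaker inhibitor), compound 1 gives 16600 nM, the highest of the two numbers, while compound 2 gives 9990 nM, within the scatter of it. Compound 3 `CCS(=O)(=O)Nc1cc(-c2ccc3ncnc(Nc4ccc(F)nc4)c3c2)cnc1OC` has not been measured; it carries 6-fluoropyridin-3-yl in place of 4-(trifluoromethoxy)phenyl on a nitrogen on an aromatic ring. With no comparable change measured, only a modest shift in either direction is expected, and compound 3 is estimated at 20000 nM (range 6000 nM to 60000 nM), a step of a 1.2-fold higher number from compound 1 to compound 3 (0.08 log units; within the scatter).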

Compound 3, half-maximal inhibitory concentration: 7620 nM
For compound 3 the middle estimate is 2.6-fold (0.42 log units) above the measured one; the measured number falls inside the stated range.
By their numbers in this assay, from the lowest: compounds 3, 2 and 1 (each within the scatter of the next, the first and the last beyond it).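

Compound 1 and compound 3 differ in one place only, and putting 6-fluoropyridin-3-yl in place of 4-(trifluoromethoxy)phenyl on this nitrogen gives a 2.2-fold lower number from compound 1 to compound 3 (0.34 log units; beyond the scatter) in this assay. The number in this assay therefore responds to the group at this position, and a group with fewer heavy atoms and a ring nitrogen does not weaken the compound. No measurement shown explains this step.

The ring nitrogen and the change of substituent arrive together, so their shares remain unseparated. As far as these compounds go, how a simple phenyl, a 4-fluorophenyl or an aryl group carrying an amine would compare also remains open.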